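A few compounds are considered here, and "the series" means these few. Any claim that something is new, unique, unknown or untested is made for them only; others in the source may bear on it.

Series notes. Compound 1 `CCCCCCCCCCc1cn(C(c2ccc(C#N)cc2)c2ccc(C#N)cc2)nn1` carries a nonyl chain on the shared core; in an assay on isolated protein for inhibition of Aromatase (Homo sapiens), read by fluorescence and colorimetric assay, with a stated time of 30 min (a lower number here means a stronger inhibitor, a higher number a weaker inhibitor), compound 1 gives 16000 nM, the highest of the two numbers in hand. Compound 2 `N#Cc1ccc(C(c2ccc(C#N)cc2)n2cc(COc3ccc([N+](=O)[O-])cc3)nn2)cc1` differs from it in one place, and in this assay compound 2 gives 7730 nM; the step of a 2.1-fold lower number from compound 1 to compound 2 (0.32 log units; beyond the scatter) is modest. Compound 3 `COc1ccc(OCc2cn(C(c3ccc(C#N)cc3)c3ccc(C#N)cc3)nn2)cc1` is not yet measured. The change from compound 1 to compound 3 is 4-methoxyphenoxy in place of nonyl on a saturated chain carbon bound to an aromatic carbon. For the measured compounds named here, only the step from compound 1 to compound 2 bears on this: the same place on the core, a substituted phenoxy group in place of the nonyl chain, and it lowered the number by a modest amount. A lowering of similar size is therefore expected for compound 3, a 2.0-fold lower number from compound 1 to compound 3 (0.30 log units; within the scatter), although the two phenoxy groups differ in their ring substituent and the data say nothing about that difference. Compound 3 is estimated at 8000 nM, expected to fall between 4000 nM and 16000 nM.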

Compound 3, half-maximal inhibitory concentration: 12200 nM
For compound 3 the middle estimate is 1.5-fold (0.18 log units) below the measured one; the measured number falls inside the stated range.
By their numbers in this assay, from the lowest: compounds 2, 3 and 1 (each within the scatter of the next, the first and the last beyond it).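

In this assay, a second phenoxy group at this place does not separate from the nonyl chain: 4-methoxyphenoxy in place of nonyl gives a 1.3-fold lower number from compound 1 to compound 3 (0.12 log units; within the scatter). The step with 4-nitrophenoxy therefore does not extend to every substituted phenoxy group, while the ring substituent change itself, methoxy in place of nitro, gives a 1.6-fold higher number from compound 2 to compound 3 (0.20 log units; within the scatter) and cannot be told apart from repeat scatter. No supporting data bear on what lies behind these numbers.

For the compounds shown here, the only step beyond the scatter at this place remains the one to compound 2, so no trend with the ring substituent can be drawn from these compounds. Going by these compounds, whether an unsubstituted phenoxy, a ring amine or a carboxylic acid in place of the nitro or methoxy group, or a shorter chain in place of nonyl, would give a clearer step remains open.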